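Cytotoxicity of Two Amide-Linked Analogues in Rat Muscle Cells

The source may report more compounds than this note shows. Statements on the series, on what has been measured and on what is new or still open speak of the compounds shown alone.

Measured so far:
- compound 1, `O=C(CCCOc1ccccc1)NCCCN1CCN(CCCNc2ccnc3cc(Cl)ccc23)CC1`: 9300 nM
- compound 2, `O=C(NCCCN1CCN(CCCNc2ccnc3cc(Cl)ccc23)CC1)c1ccc(C(=O)c2ccccc2)cc1`: "not determined" (no result reported)

The common core is the structure seen in compound 1. Among the measured compounds shown here, in an ADME assay on L6 cells (Rattus norvegicus) for cytotoxicity (on this read-out lower numbers stand for stronger inhibition and higher numbers for weaker inhibition), compound 1 gives 9300 nM, the only number available; compound 2 carries no result, so compound 1 stands alone and cannot be ranked. Compound 3, `O=C(NCCCN1CCN(CCCNc2ccnc3cc(Cl)ccc23)CC1)c1ccc(Cl)c([N+](=O)[O-])c1`, has not yet been measured. It differs from compound 1 in one place: 4-chloro-3-nitrophenyl in place of 3-phenoxypropyl on a carbonyl carbon. For the measured compounds named here, no measured pair shows what such a change does here, so the size of the step is unknown. In the absence of any comparable step, the expectation for compound 3 is a value close to that of compound 1, with the step of a 1.3-fold lower number from compound 1 to compound 3 (0.12 log units; within the scatter) expected to be small and possibly within scatter. Compound 3 is therefore estimated at 7000 nM, between 2500 nM and 25000 nM.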

Compound 3, half-maximal inhibitory concentration: 11300 nM
The estimate for compound 3 lay 1.6-fold (0.21 log units) below the measured number; low and high end bracket the measured number.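

In this assay the exchange of 3-phenoxypropyl for 4-chloro-3-nitrophenyl on the carbonyl carbon gives a 1.2-fold higher number from compound 1 to compound 3 (0.08 log units; within the scatter) and so leaves the two compounds indistinguishable on this read-out. At this one position, then, a chain ending in a phenoxy group and a ring carrying chlorine and nitro substituents give the same result within the scatter, which a single measured compound could not show. Nothing measured here explains this outcome.

A single pair cannot show whether this position stays this forgiving with other groups, such as a basic amine, a carboxylic acid or a longer alkyl chain. Compound 2 has no number, so any step involving it cannot be read.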